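A few compounds are considered here, and "the series" means these few. Any claim that something is new, unique, unknown or untested is made for them only; others in the source may bear on it.

Measured compounds:
compound 1 `C[Se]/C(=N\C(=O)c1cc2ccccc2s1)NC(=O)c1cc2ccccc2s1`, 61000 nM
compound 2 `CS/C(=N\C(=O)c1csc([N+](=O)[O-])c1)NC(=O)c1csc([N+](=O)[O-])c1`, 98700 nM
compound 3 `CS/C(=N\C(=O)c1ccno1)NC(=O)c1ccno1`, > 100000 nM

In a functional assay on K562 cells (Homo sapiens) for cytotoxicity, read by MTT assay, with a stated time of 72 h (a lower number here means a stronger inhibitor of growth, a higher number a weaker inhibitor of growth), compound 1 gives 61000 nM, the lowest of the two numbers obtained. Compound 2 gives 98700 nM, and the gap from compound 1 to compound 2 lies within the scatter, so no order between the two can be read. For the measured compounds named here, compound 3 returns only a limit of the assay, > 100000 nM; it is the one value that sits at the limit (the limit of > 100000 nM in this assay, at which 1 of the 3 values shown sits), not a number.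

Compound 4 `CS/C(=N\C(=O)c1cc2ccccc2s1)NC(=O)c1cc2ccccc2s1` keeps the core of compound 1 and differs from it in one place: a group of 2 heavy atoms (1 carbon, 1 sulfur; no ring) in place of a group of 2 heavy atoms (1 carbon, 1 selenium; no ring), on a carbon with a double bond to nitrogen. Going by the values given here, no measured pair shows this exchange on its own, so the step has to be judged without a direct precedent. The two methylsulfanyl compounds measured, compound 2 and compound 3, both sit at the weak end of the range seen, which is the only pointer available.

Compound 4 is expected to sit near or beyond the upper end of the measured range, with the step from compound 1 to compound 4 estimated as a 1.8-fold higher number from compound 1 to compound 4 (0.26 log units; within the scatter). The estimate for compound 4 in this assay is 110000 nM, with a likely range from 45000 nM to 260000 nM, and a real chance that only a limit is reported.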

Compound 4, concentration for total growth inhibition: 66600 nM
Beside the measured number, compound 4's estimate is 1.7-fold (0.22 log units) above it; the range from low to high includes it.
By their numbers in this assay, from the lowest: compounds 1, 4 and 2 (each within the scatter of the next). At a limit, above all of these: compound 3.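

In this assay, replacing the selenium-bearing group with methylsulfanyl, on a carbon with a double bond to nitrogen, gives a 1.1-fold higher number from compound 1 to compound 4 (0.04 log units; within the scatter). This is the first direct reading of any change at this place: on the shared core, the selenium and sulfur groups cannot be told apart in this assay, so the selenium atom is not shown to be required for the growth inhibition seen with compound 1. Nothing in the data at hand bears on why the two groups read alike.

Still open, on these data alone, is whether an amine, or a longer chain in place of the methyl on sulfur, would move the number beyond the scatter. Also open, as far as these compounds go, is whether the exchange of sulfur for selenium reads the same on the cores of compound 2 and compound 3.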